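Aryl swap at the chain carbon in the chromene series

A few compounds are considered here, and "the series" means these few. Any claim that something is new, unique, unknown or untested is made for them only; others in the source may bear on it.

Compound 2 `COc1ccc(C(=O)/C=C/c2ccco2)c2c1C=CC(C)(C)O2` is one of the two compounds measured in a functional assay on K562 cells (Homo sapiens) for antiproliferative activity, read by MTT assay, with a stated time of 24 h; on this read-out lower numbers stand for stronger inhibition and higher numbers for weaker inhibition. In this assay compound 2 reaches only a limit of the assay, > 10000 nM. Compound 1 `COc1ccc(C(=O)/C=C/c2cccc([N+](=O)[O-])c2)c2c1C=CC(C)(C)O2` carries 3-nitrophenyl at the same place, and in this assay compound 1 gives 5870 nM. Within the data shown here, the single step joining them, an at least 1.7-fold higher number from compound 1 to compound 2 (0.23 log units; that floor lies within the scatter), is known only as a floor since compound 2 sits at the limit of > 10000 nM in this assay, at which 1 of the 2 values shown sits. Compound 3 `COc1ccc(C(=O)/C=C/c2cccc(O)c2)c2c1C=CC(C)(C)O2` is yet to be measured; (3-hydroxyphenyl in place of furan-2-yl on a double-bonded chain carbon bound to a double-bonded chain carbon). Among the measured compounds shown here, only the step from compound 1 to compound 2 bears on this change, and both exchange one aryl group at the same chain carbon. The step of an at least 1.4-fold lower number from compound 2 to compound 3 (0.15 log units; that floor lies within the scatter) is therefore expected as a decrease in the number, back toward compound 1 at 5870 nM. Compound 3 is estimated at 7000 nM, with a range from 3000 nM to 20000 nM.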

Compound 3, half-maximal inhibitory concentration: > 10000 nM
Compound 3: a limit, no number; the forecaster's own chance of this, stated with the estimate: 35%; middle value at least 1.4-fold (0.15 log units) away from the limit.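

In this assay compound 3 also reaches only a limit of the assay, > 10000 nM. With hydroxy in place of nitro on an aromatic carbon, the record gives an at least 1.7-fold higher number from compound 1 to compound 3 (0.23 log units; that floor lies within the scatter), so this floor, like the one for furan-2-yl, establishes no loss relative to compound 1, and 3-hydroxyphenyl joins furan-2-yl in yielding no number at this chain carbon. The step between compound 2 and compound 3 cannot be read, since both values are limits: the limit of > 10000 nM in this assay, at which 2 of the 3 values shown sit.

Among the compounds shown, only compound 1 gives a number, 5870 nM, so the series has no second measured value against which to compare aryl groups at this position. Open, on these data alone, is whether an amine or a carboxylic acid in place of the hydroxy on the aromatic carbon would give a measurable value in this assay.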